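This account rests on a few compounds, and the source may have more. Where it says the series, first, only, none or still open, it means among the compounds named here.

Of the compounds shown here, two built on the same core have been measured. Compound 1 `COc1ccc(Nc2cc(C3CCCCC3)oc(=O)c2)cc1` carries a cyclohexyl group on the aromatic ring, while compound 2 `O=c1cc(Nc2ccc(Br)cc2)cc(-c2ccccc2)o1` carries a phenyl group there and a bromine on the aniline part. In a functional assay on A549 cells (Homo sapiens) for cytotoxicity, read by MTT assay, with a stated time of 72 h (a lower number here means that less compound is needed, a higher number that more compound is needed for the effect), compound 1 gives 4.62 uM, and compound 2 gives 0.31 uM. Compound 1 thus stands at the higher of the two numbers, and the gap to compound 2 lies well beyond the usual scatter.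

Compound 3 `CCCCCc1cc(Nc2ccc(OC)cc2)cc(=O)o1` has not yet been measured. It differs from compound 1 in one place: pentyl in place of cyclohexyl on an aromatic carbon, on an aromatic carbon of a six-membered aromatic ring with 1 oxygen. For the measured compounds named here, a chain of five carbons in place of a ring of six carbons is a modest alteration, and no measured pair shows what such a swap does here. The expectation is a step of a 1.1-fold higher number from compound 1 to compound 3 (0.03 log units; within the scatter) that stays within the scatter in this assay. Compound 3 is therefore estimated at 5 uM, in a range from 1.5 uM to 16 uM.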

Compound 3, concentration for half-maximal effect: 4.42 uM
For compound 3 the middle estimate is 1.1-fold (0.05 log units) above the measured one; low and high end bracket the measured number.
By their numbers in this assay, from the lowest: compound 2; then compounds 3 and 1 (each within the scatter of the next).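

In this assay pentyl in place of cyclohexyl gives a 1.0-fold lower number from compound 1 to compound 3 (0.02 log units; within the scatter) and this step lies within the scatter, so the two compounds cannot be told apart. For this position, on an aromatic carbon next to the ring oxygen, this pair shows that a closed ring of carbons is not needed to keep this level of cytotoxicity, since an open chain does as well here. No measurement at hand explains why the two groups give such a close match.

As far as these compounds go, whether a shorter chain such as ethyl, or a chain ending in an amine or a carboxylic acid, would hold this level at the same position remains open. From the compounds shown here alone, it is also open whether pentyl and cyclohexyl would still match with a group other than methoxy on the aniline ring.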